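Thiazole Substituent Change and Guinea Pig Inhibition

This account rests on a few compounds, and the source may have more. Where it says the series, first, only, none or still open, it means among the compounds named here.

Compound 1: `COc1ccc(-c2nc(CCO)sc2-c2ccc(OC)cc2)cc1`, 9%
Compound 2: `COC(=O)C(C)(C)c1nc(-c2ccc(OC)cc2)c(-c2ccc(OC)cc2)s1`, 27%

In a functional assay on the whole organism for inhibition, with Cavia porcellus as the target, at a dose of 1 mg/kg by the oral route (on this read-out lower numbers stand for a weaker effect and higher numbers for a stronger effect at the one dose given), compound 2 stands highest of the two measured numbers, and its nearest neighbour is compound 1, which gives 9%. Among the compounds with values here, the one measured step, a number 18 percentage points higher from compound 1 to compound 2 (beyond the scatter), shows that the group on this aromatic carbon can shift the read-out beyond the scatter. Compound 3, `COc1ccc(-c2nc(C(F)(F)F)sc2-c2ccc(OC)cc2)cc1`, differs from compound 2 by trifluoromethyl in place of 1-(methoxycarbonyl)-1-methylethyl on an aromatic carbon. Within the data shown here, no measured step covers trifluoromethyl, so only the size of the step from compound 1 to compound 2 guides the expectation. Compound 3 is expected to give 15% (range 2% to 32%), an estimated change of a number 12 percentage points lower from compound 2 to compound 3 (beyond the scatter).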

Compound 3, a percentage reported as inhibition, in the whole organism at one dose (the size of the read-out at that dose, not a potency): 83%
Beside the measured number, compound 3's estimate is 68 percentage points below it; the whole stated range lies below it.
By their numbers in this assay, from the lowest: compound 1; then compound 2; then compound 3.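

Trifluoromethyl in place of 1-(methoxycarbonyl)-1-methylethyl gives a number 56 percentage points higher from compound 2 to compound 3 (beyond the scatter) in this assay, and in place of 2-hydroxyethyl it gives a number 74 percentage points higher from compound 1 to compound 3 (beyond the scatter), so this aromatic carbon can move the read-out far more than a number 18 percentage points higher from compound 1 to compound 2 (beyond the scatter) had shown. Of the three groups seen at this place, trifluoromethyl, with no hydrogen-bond donors or acceptors, stands with the highest number. Nothing at hand gives a reason for a step of this size. As far as these compounds go, whether a methyl group, a chlorine atom or a nitrile on this carbon would give a similar number stays open. So does how a carboxylic acid in place of the ester of compound 2 would compare.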